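Cytotoxicity of a Fused Acetal Series on HEL Cells

This account rests on a few compounds, and the source may have more. Where it says the series, first, only, none or still open, it means among the compounds named here.

Measured so far:
compound 1 `CO[C@@H]1[C@@H](OC)[C@H](Cc2ccccc2)O[C@@H]2CO[C@@H](c3ccccc3)O[C@@H]12`: > 50 ug/mL
compound 2 `CO[C@@H]1[C@@H](OC)[C@H](c2ccccc2)O[C@@H]2CO[C@@H](c3ccco3)O[C@@H]12`: "not determined" (no result reported)

In a functional assay on HEL cells (Homo sapiens) for cytotoxicity (a higher number here means that more compound is tolerated, a lower number that less compound is tolerated), compound 1 gives only a limit, > 50 ug/mL, not a number. For the measured compounds named here, for compound 2 no result was obtained in this assay, so it stands on no number here; the one value shown is that limit (the limit of > 50 ug/mL in this assay, at which 1 of the 2 values shown sits). Compound 3 `CO[C@@H]1[C@@H](OC)[C@H](c2ccccc2)O[C@@H]2CO[C@@H](c3ccc(C(F)(F)F)cc3)O[C@@H]12` differs from compound 2 by 4-(trifluoromethyl)phenyl in place of furan-2-yl on a saturated ring carbon. Going by the values given here, with no measured step between two compounds to lean on, the size of this step in this assay cannot be read from the data, and none beyond the scatter is assumed. Compound 3 is expected to give about 50 ug/mL, within 20 ug/mL to 100 ug/mL.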

Compound 3, half-maximal cytotoxic concentration: > 50 ug/mL
Compound 3 ended at the assay's limit; the forecaster's own chance of this, stated with the estimate: 60%; the middle value lies on the limit itself.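

For the compounds shown here, compound 2 has no result in this assay and compound 3 gives only a limit, so no step between them can be read. The compounds shown leave open at what concentration either one harms these cells.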